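Two-carbon extension on the sulfonamide of a urea

The source may report more compounds than this note shows. Statements on the series, on what has been measured and on what is new or still open speak of the compounds shown alone.

Three compounds share a urea core and differ only in the group on a sulfonyl sulfur. Compound 3 `CN(C)S(=O)(=O)c1ccc(NC(=O)NCc2ccncc2)cc1` gives 3110 nM in an assay on isolated protein for activation of Nicotinamide phosphoribosyltransferase (Homo sapiens) (a lower number here means that less compound is needed, a higher number that more compound is needed for the effect), and stands highest of the three numbers. Compound 1 `O=C(NCc1ccncc1)Nc1ccc(S(=O)(=O)N2CC3CCC(C2)O3)cc1` gives 279 nM, and compound 2 `O=C(NCc1ccncc1)Nc1ccc(S(=O)(=O)c2ccc(Cl)cc2)cc1` gives 126 nM in this assay. The steps of an 11-fold higher number from compound 1 to compound 3 (1.05 log units; beyond the scatter) and a 25-fold higher number from compound 2 to compound 3 (1.39 log units; beyond the scatter) show that the small dimethylamino group on the sulfonyl sulfur goes with the highest number, while a 2.2-fold lower number from compound 1 to compound 2 (0.35 log units; beyond the scatter) separates the two larger groups from each other only modestly.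

Compound 4 `CCN(CC)S(=O)(=O)c1ccc(NC(=O)NCc2ccncc2)cc1` carries diethylamino in place of dimethylamino on a sulfonyl sulfur. Among the measured compounds shown here, no measured pair tests this particular change. The two large steps concern groups of quite different size and ring content, so two added carbons on a non-ring amine are expected to move the number only modestly, most likely downward. The expected step is a 1.6-fold lower number from compound 3 to compound 4 (0.19 log units; within the scatter). Compound 4 is therefore estimated at 2000 nM in this assay, within a range of 700 nM to 6000 nM.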

Compound 4, half-maximal effective concentration: 384 nM
Compound 4: the middle estimate sits 5.2-fold (0.72 log units) above what was measured, and the stated range ends above it.
By their numbers in this assay, from the lowest: compound 2; then compounds 1 and 4 (each within the scatter of the next); then compound 3.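

In this assay, the change from dimethylamino to diethylamino on the sulfonyl sulfur is enough on its own to give a step beyond the scatter (an 8.1-fold lower number from compound 3 to compound 4 (0.91 log units; beyond the scatter)), so the position responds to a small change in an open-chain amine and not only to the much larger exchanges seen earlier. Diethylamino, which has no ring, lies within the scatter of the bridged ring group of compound 1 (a 1.4-fold higher number from compound 1 to compound 4 (0.14 log units; within the scatter)), whereas 4-chlorophenyl remains apart from it (a 3.0-fold higher number from compound 2 to compound 4 (0.48 log units; beyond the scatter)), so a ring on the amine is not needed to leave the range of compound 3. Nothing available explains why this exchange has this effect.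

Going by these compounds, it remains open whether a longer chain, such as dipropylamino, would continue this direction or reverse it. A mixed ethylmethylamino group or a simple ring amine such as pyrrolidine would show how much of the step needs both ethyl groups free.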